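The source may hold more compounds than are shown below. What is called first, only, known or untested is meant among the compounds shown, and "the series" means these compounds.

Compound 1 `CCOC(=O)CN(Cc1ccccc1)c1nc(NCc2cccc(OC)c2)ncc1[N+](=O)[O-]`: > 100000 nM in a functional assay on A549 cells (Homo sapiens) for antiproliferative activity, read by MTT assay, with a stated time of 48 h; a higher number here means a weaker inhibitor, a lower number a stronger inhibitor.
Compound 2 `CCOC(=O)CNc1nc(NCc2ccccc2)ncc1[N+](=O)[O-]`: 74400 nM in this assay.
Compound 3 `COC(=O)CN(C)c1nc(Nc2ccccc2)ncc1[N+](=O)[O-]`: > 100000 nM in this assay.

The value for compound 1 is a limit of this assay, not a number. The same holds for compound 3. (the limit of > 100000 nM in this assay, at which 2 of the 3 values shown sit). Within the data shown here, compound 2 is the only one with a number, and it sits close to that limit. Compound 4 `CCOC(=O)CN(Cc1ccccc1)c1nc(Nc2cc(OC)c(OC)c(OC)c2)ncc1[N+](=O)[O-]` differs from compound 1 in one place: 3,4,5-trimethoxyphenyl in place of 3-methoxybenzyl on a nitrogen on an aromatic ring. Among the measured compounds shown here, no measured pair shows this change, so no step size can be read from the series. With compound 1 at a limit and compound 2 not far from it, any step in this assay is expected to be small and to stay near the limit, with no direction supported beyond the scatter. Compound 4 is expected to give 80000 nM, between 20000 nM and 300000 nM, with a fair chance the result is again only a limit. The step from compound 1 to compound 4 is estimated as an at least 1.2-fold lower number from compound 1 to compound 4 (0.09 log units; that floor lies within the scatter).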

Compound 4, half-maximal inhibitory concentration: > 100000 nM
Compound 4: no number, only a limit; the forecaster's own chance of this, stated with the estimate: 55%; middle value at least 1.2-fold (0.09 log units) from the limit.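

No step can be read from compound 1 to compound 4 in this assay, as both values are limits: the limit of > 100000 nM in this assay, at which 3 of the 4 values shown sit.

From the compounds shown here alone, whether 3,4,5-trimethoxyphenyl and 3-methoxybenzyl differ at all stays open.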